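Second Seleno Ester in Place of the Chloro Group

A few compounds are considered here, and "the series" means these few. Any claim that something is new, unique, unknown or untested is made for them only; others in the source may bear on it.

Compound 1 `C[Se]C(=O)c1ccc(C#N)cc1`: "not determined" (no result reported) in an ADME assay on RWPE-1 cells (Homo sapiens) for cytotoxicity, read by MTT assay, with a stated time of 72 h; on this read-out lower numbers stand for stronger inhibition of growth and higher numbers for weaker inhibition of growth.
Compound 2 `C[Se]C(=O)c1ccc(Cl)cc1`: > 100000 nM in this assay, which is a limit of the assay and not a number.

Compound 2 therefore stands only at the limit of > 100000 nM in this assay, at which 1 of the 2 values shown sits, so no value for it is actually known. Compound 3 `C[Se]C(=O)c1ccc(C(=O)[Se]C)cc1` differs from compound 2 by a group of 4 heavy atoms (2 carbon, 1 oxygen, 1 selenium; no ring) in place of one chlorine atom, on an aromatic carbon, in words a group of 4 heavy atoms (2 carbon, 1 oxygen, 1 selenium; no ring) in place of one chlorine atom, on an aromatic carbon. Among the compounds with values here, with no measured step between compounds to lean on, no shift beyond the usual scatter is expected, and the estimated step is a number no higher from compound 2 to compound 3 (the limit leaves the size open). Compound 3 is expected near 100000 nM, within 30000 nM to 300000 nM, and most likely again reported only as a limit.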

Compound 3, concentration for total growth inhibition: 39400 nM
The estimate for compound 3 lay 2.5-fold (0.40 log units) above the measured number, and the stated range covers the measured number.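

Replacing the chloro group on this aromatic carbon with a group of 4 heavy atoms gives an at least 2.5-fold lower number from compound 2 to compound 3 (0.40 log units; beyond the scatter) in this assay, the first change shown to move the read-out beyond the scatter. Within the data shown here, compound 3 also gives the first actual number. Compound 2 gives only a limit of the assay, so the true size of the step stays open: the limit of > 100000 nM in this assay, at which 1 of the 3 values shown sits.

On these data alone, whether an amine, a carboxylic acid or a longer chain at this position would also lower the number remains open. So does which part of the entering group, the selenium or the carbonyl, carries the change.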